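Aryl swap at the amide-type nitrogen: outlook for compound 3

A few compounds are considered here, and "the series" means these few. Any claim that something is new, unique, unknown or untested is made for them only; others in the source may bear on it.

Measured so far:
compound 1 `Cc1ccc(NC(=O)Nc2ccccc2F)cc1S(=O)(=O)N(C)C` — an assay on HEK293 cells for activation of Kir3.1/Kir3.2 (Homo sapiens), read by fluorescence and thallium flux, with a stated time of 4 min; a lower number here means that less compound is needed, a higher number that more compound is needed for the effect: 3900 nM
compound 2 `Cc1ccc(NC(=O)Nc2ccccc2Cl)cc1S(=O)(=O)N(C)C` — this assay : 2700 nM

Compound 2 gives the lower of the two numbers in this assay; its nearest neighbour is compound 1, and the step of a 1.4-fold lower number from compound 1 to compound 2 (0.16 log units; within the scatter) lies within the scatter, so the two cannot be ordered.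

Compound 3 `Cc1ccc(NC(=O)Nc2cccc(C#N)c2)cc1S(=O)(=O)N(C)C` is not yet measured. It differs from compound 2 in 3-cyanophenyl in place of 2-chlorophenyl on an amide-type nitrogen. For the measured compounds named here, no measured step bears on this change: the only step on record swaps one halogen for another on an aromatic carbon and stays within the scatter, which says nothing about exchanging a 2-chlorophenyl for a 3-cyanophenyl. With no further guide, no step beyond the scatter is expected in either direction, the estimated change being a 1.1-fold higher number from compound 2 to compound 3 (0.05 log units; within the scatter). Compound 3 is therefore expected at 3000 nM in this assay, between 700 nM and 13000 nM.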

Compound 3, half-maximal effective concentration: 3900 nM
For compound 3 the middle estimate is 1.3-fold (0.11 log units) below the measured one; the measured number falls inside the stated range.
By their numbers in this assay, from the lowest: compounds 2, 1 and 3 (each within the scatter of the next).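

In this assay, 3-cyanophenyl in place of 2-chlorophenyl on the amide-type nitrogen gives a 1.4-fold higher number from compound 2 to compound 3 (0.16 log units; within the scatter), and 3-cyanophenyl in place of 2-fluorophenyl gives no change at the digits printed from compound 1 to compound 3 (within the scatter). Unlike the earlier halogen swap, these changes replace the whole aryl group and bring in a nitrile, counted as a hydrogen-bond acceptor, yet neither step goes beyond the scatter, so all three aryl groups remain indistinguishable at this position. Nothing available explains why these values stay so close.

The compounds shown do not separate the effect of the nitrile from that of its place on the ring. As far as these compounds go, it also remains open whether a carboxylic acid, an aminomethyl group or a methoxy group on this ring, or an unsubstituted phenyl, would give a step beyond the scatter.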